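Carbonyl group swap: prop-1-en-1-yl to cyclopropyl

This account rests on a few compounds, and the source may have more. Where it says the series, first, only, none or still open, it means among the compounds named here.

All values below come from a functional assay on MGC-803 cells (Homo sapiens) for inhibition, read by MTT assay, with a stated time of 48 h (on this read-out higher numbers stand for weaker inhibition and lower numbers for stronger inhibition), as measured so far

- compound 1 `C#CC(=O)N(Cc1ccc(OC)c(O)c1)c1cc(OC)c(OC)c(OC)c1` gives 170 nM
- compound 2 `COc1ccc(CN(C(=O)CO)c2cc(OC)c(OC)c(OC)c2)cc1O` gives 160 nM
- compound 3 `C/C=C/C(=O)N(Cc1ccc(OC)c(O)c1)c1cc(OC)c(OC)c(OC)c1` gives 27 nM

Compound 3 has the lowest number of the three, and its steps from both others lie beyond the scatter (a 6.3-fold lower number from compound 1 to compound 3 (0.80 log units; beyond the scatter); a 5.9-fold lower number from compound 2 to compound 3 (0.77 log units; beyond the scatter)). Compound 4 `COc1ccc(CN(C(=O)C2CC2)c2cc(OC)c(OC)c(OC)c2)cc1O` is still unmeasured. It carries cyclopropyl in place of prop-1-en-1-yl on a carbonyl carbon.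

Only the three measured steps bear on this change, since all of them fall at the same carbonyl carbon. Ethynyl to hydroxymethyl gave nothing beyond the scatter (a 1.1-fold lower number from compound 1 to compound 2 (0.03 log units; within the scatter)), whereas the two steps to prop-1-en-1-yl were modest. Going by the values given here, no measured compound has a ring at this carbon, so direct precedent is lacking. With compound 3 at 27 nM and no lower number in the series, an upward move is more likely than a downward one, probably no larger than those two modest steps. The expected step is a 2.2-fold higher number from compound 3 to compound 4 (0.35 log units; beyond the scatter) and remains an estimate. The expected value for compound 4 is 60 nM with an estimated range from 18 nM to 200 nM in this assay for now.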

Compound 4, half-maximal inhibitory concentration: 59 nM
Beside the measured number, compound 4's estimate is 1.0-fold (0.01 log units) above it; measured number inside the range.
By their numbers in this assay, from the lowest: compound 3; then compound 4; then compounds 2 and 1 (each within the scatter of the next).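

In this assay, cyclopropyl puts the first ring at this carbonyl carbon and places compound 4 in the middle of the series: the number rises on leaving prop-1-en-1-yl (a 2.2-fold higher number from compound 3 to compound 4 (0.34 log units; beyond the scatter)), yet falls relative to the hydroxymethyl compound (a 2.7-fold lower number from compound 2 to compound 4 (0.43 log units; beyond the scatter)) and the ethynyl compound (a 2.9-fold lower number from compound 1 to compound 4 (0.46 log units; beyond the scatter)). A double bond outside aromatic rings is therefore not needed at this position for a number below those of compound 1 and compound 2, although compound 3, which has one, keeps the lowest number of the four. No available evidence accounts for the size of these steps.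

A propyl group at the same carbonyl carbon would show whether the rise from compound 3 to compound 4 goes with the loss of the double bond or with the ring itself. Cyclobutyl, a longer chain such as butyl, an amine and a carboxylic acid also remain open here, so how far this position extends beyond the four groups shown cannot be said.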